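From 4-hydroxyphenyl to phenyl on a shared core

The source may hold more compounds than are shown below. What is called first, only, known or untested is meant among the compounds shown, and "the series" means these compounds.

Compound 1 `Clc1ccc(-c2nnc(SCCCN3CCN(c4nc5ccccc5o4)CC3)o2)cc1`: 99700 nM
Compound 2 `Oc1ccc(-c2nnc(SCCCN3CCN(c4nc5ccccc5o4)CC3)o2)cc1`: 260000 nM

In a functional assay on MCF7 cells (Homo sapiens) for inhibition, read by MTT assay, with a stated time of 72 h (on this read-out higher numbers stand for weaker inhibition and lower numbers for stronger inhibition), compound 2 gives 260000 nM as the higher of the two numbers. Compound 3 `c1ccc(-c2nnc(SCCCN3CCN(c4nc5ccccc5o4)CC3)o2)cc1` differs from it by hydrogen in place of hydroxy on an aromatic carbon. Among the measured compounds shown here, only one measured step bears on this place: a 2.6-fold higher number from compound 1 to compound 2 (0.42 log units; beyond the scatter) on putting hydroxy in place of chloro. That step is modest and does not involve hydrogen, so only a small move to a lower number is expected. The expected change is a 1.7-fold lower number from compound 2 to compound 3 (0.24 log units; within the scatter) in this read-out. Compound 3 is estimated at 150000 nM (range 70000 nM to 320000 nM).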

Compound 3, half-maximal inhibitory concentration: 117000 nM
The estimate for compound 3 lay 1.3-fold (0.11 log units) above the measured number; the measured number falls inside the stated range.
By their numbers in this assay, from the lowest: compounds 1 and 3 (each within the scatter of the next); then compound 2.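

In this assay the hydroxy group proves to be the substituent that stands apart at this position, since hydrogen in its place gives a 2.2-fold lower number from compound 2 to compound 3 (0.35 log units; beyond the scatter) and the change lies beyond the scatter. Hydrogen and chloro on this aromatic carbon cannot be told apart, with a 1.2-fold higher number from compound 1 to compound 3 (0.07 log units; within the scatter) inside the scatter. Nothing measured here accounts for this difference.

The compounds shown leave open whether a methoxy or an amino group on this carbon would fall with compound 2 or with compound 1 and compound 3.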